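The source may hold more compounds than are shown below. What is called first, only, known or untested is meant among the compounds shown, and "the series" means these compounds.

Working notes on the series. The shared core of compound 1 `COc1ccc(N2CCN(Cc3csc(N)c3C(=O)c3ccc(Cl)cc3)CC2)cc1` carries a piperazine whose aryl substituent is the point of variation. In a functional assay on CHO cells with adenosine receptor A1 (Homo sapiens) as the target, read by cAMP accumulation and immunoassay, with a stated time of 6 min, tested at 0.1 uM (a lower number here means a stronger effect, a higher number a weaker effect of the compound at the concentration tested), compound 1 gives 0%. Compound 2 `Nc1scc(CN2CCN(c3ccc([N+](=O)[O-])cc3)CC2)c1C(=O)c1ccc(Cl)cc1` gives -13% in this assay and stands lowest of the two numbers, with compound 1 nearest. For the measured compounds named here, the one measured step, a number 13 percentage points lower from compound 1 to compound 2 (beyond the scatter), is modest and lies beyond the scatter, though both numbers sit close to no effect at the concentration used.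

Compound 3 `Nc1scc(CN2CCN(c3ccc(F)c(F)c3)CC2)c1C(=O)c1ccc(Cl)cc1` differs from compound 2 only at that aryl substituent: 3,4-difluorophenyl in place of 4-nitrophenyl on an amine nitrogen in a ring. The step from compound 1 to compound 2 bears on this change in that it varies the same position of the same core, and it was small; nothing further is measured for an aryl group without hydrogen-bond acceptors. Compound 3 is therefore expected to remain near the level of compound 2, with a step of a number 8 percentage points higher from compound 2 to compound 3 (within the scatter) in this assay that is not expected to exceed the scatter. The estimate for compound 3 in this assay is -5%, with a range from -25% to 15%.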

Compound 3, a percentage reported as activity, at one concentration (the size of the read-out at that concentration, not a potency): -34%
Beside the measured number, compound 3's estimate is 29 percentage points above it, outside the stated range (below it).
By their numbers in this assay, from the lowest: compound 3; then compound 2; then compound 1.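

In this assay, for the compounds shown here, the aryl group on an amine nitrogen in a ring proves able to move the read-out further than the first pair indicated: 3,4-difluorophenyl in place of 4-nitrophenyl gives a number 21 percentage points lower from compound 2 to compound 3 (beyond the scatter) and, set against the 4-methoxyphenyl group, it gives a number 34 percentage points lower from compound 1 to compound 3 (beyond the scatter) as the only step graded large. Compound 3 therefore holds the lowest number of the three, with its steps to both other compounds printed as beyond the scatter, so this position spans a wider range of effect at the tested concentration than a number 13 percentage points lower from compound 1 to compound 2 (beyond the scatter) had shown on its own. Nothing at hand accounts for the direction or size of this change.

Still open, as far as these compounds go, is whether both fluorines are needed for the lower number, which 4-fluorophenyl, 3-fluorophenyl and unsubstituted phenyl at the same position would help to separate. Also open, from the compounds shown here alone, is whether other groups on this aryl ring, such as chlorine or trifluoromethyl, would extend the trend, and whether the ranking seen at this single concentration would hold as a ranking of potency.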